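Working notes: from compound 2 to compound 3

The source may report more compounds than this note shows. Statements on the series, on what has been measured and on what is new or still open speak of the compounds shown alone.

Compound 1 `O=C1C(=Cc2ccc(Br)cc2)C(=O)N(c2ccc(Cl)cc2)N1c1ccc(Cl)cc1`: 12300 nM
Compound 2 `O=C1C(=Cc2cccc(Cl)c2)C(=O)N(c2ccc(Cl)cc2)N1c1ccc(Cl)cc1`: 22600 nM

Both values come from a functional assay on ECa-109 cells (Homo sapiens) for cytotoxicity, read by MTT assay, with a stated time of 72 h; a lower number here means a stronger inhibitor, a higher number a weaker inhibitor. For the measured compounds named here, compound 2 stands within the scatter of the only other measured compound, and the one measured step, a 1.8-fold higher number from compound 1 to compound 2 (0.26 log units; within the scatter), changes the same place. Compound 3 `O=C1C(=Cc2ccc(Cl)cc2Cl)C(=O)N(c2ccc(Cl)cc2)N1c1ccc(Cl)cc1` carries 2,4-dichlorophenyl in place of 3-chlorophenyl on a double-bonded chain carbon bound to a double-bonded ring carbon. Going by the values given here, with only that step to go on, no shift beyond the scatter and no direction is expected in this assay. The expected change is a 1.3-fold lower number from compound 2 to compound 3 (0.12 log units; within the scatter). For compound 3 the estimate is 17000 nM, with an expected range of 7000 nM to 40000 nM.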

Compound 3, half-maximal inhibitory concentration: 60200 nM
Compound 3: the middle estimate sits 3.5-fold (0.55 log units) below what was measured; the measured number lies above the stated range.
By their numbers in this assay, from the lowest: compounds 1 and 2 (each within the scatter of the next); then compound 3.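

In this assay, the place on a double-bonded chain carbon bound to a double-bonded ring carbon now shows a change beyond the scatter: 2,4-dichlorophenyl gives a 2.7-fold higher number from compound 2 to compound 3 (0.43 log units; beyond the scatter) and also a 4.9-fold higher number from compound 1 to compound 3 (0.69 log units; beyond the scatter). The 4-bromophenyl and 3-chlorophenyl of the earlier pair did not separate, so among these compounds this place is not indifferent to the group it carries. Nothing at hand accounts for the shift. Going by these compounds, whether it follows the second chlorine or the positions of the chlorines stays open, as does the effect of an amine or a carboxylic acid on the phenyl ring here.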